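The compounds below may be only part of what the source reports. "The series", "measured", "known", "first", "only" and "open" are said of these compounds alone.

Compound 3 `C=C(C)CCC1(C=C(C)C)C(=O)C2=C(O)[C@H](C)[C@@H](C)OC2=C(C(CC(=O)O)c2ccccc2)C1=O` is one of three compounds tested in a functional assay on cells for cytotoxicity; a higher number here means a weaker inhibitor, a lower number a stronger inhibitor. In this assay compound 3 gives > 20 ug/mL, which is a limit of the assay and not a number. Compound 1 `C=C(C)[C@@H]1C[C@@H](CC2(CC=C(C)C)C(=O)C3=C(O)[C@@H](C)[C@@H](C)OC3=C(C(CC(=O)O)c3ccccc3)C2=O)C1(C)C` in this assay gives > 20 ug/mL, again a limit rather than a number. Compound 2 `C=C(C)[C@@H]1C[C@@H](CC2(CC=C(C)C)C(=O)C3=C(O)[C@@H](C)[C@H](C)OC3=C(C(CC(=O)O)c3ccccc3)C2=O)C1(C)C` in this assay gives > 20 ug/mL, also a limit. Among the three measured compounds only compound 1 and compound 2 differ in one place, where a stereocentre at a saturated ring carbon is drawn R in compound 1 and S in compound 2; the step that the two limits leave unreadable from compound 1 to compound 2 cannot be read, because the limit of > 20 ug/mL in this assay, at which 3 of the 3 values shown sit, and because of the fact that one of compounds 1 and 2 is drawn with a defined configuration and the other without, at the place where they differ. Compound 4 `C=C(C)CCC1(C=C(C)C)C(=O)C2=C(O)[C@H](C)[C@H](C)OC2=C(C(CC(=O)O)c2ccccc2)C1=O` stands to compound 3 as compound 2 stands to compound 1: the two compounds have the same atoms and bonds; at least one stereo element is drawn with a configuration in one of them and without one in the other: 1 of 4 stereo elements differ; a stereocentre at a saturated ring carbon is drawn R in compound 3 and S in compound 4. Among the compounds with values here, the single comparable step offers no readable size, so it gives no ground to expect a change beyond the scatter, and with every measured value sitting at the limit, compound 4 would most likely reach that limit as well. Compound 4 is therefore expected to give 30 ug/mL in this assay, with a range from 15 ug/mL to 100 ug/mL. The step this estimate means, a step that the limit leaves unreadable from compound 3 to compound 4, is expected to lie within the scatter.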

Compound 4, half-maximal inhibitory concentration: > 20 ug/mL
Compound 4 gave a limit, no number; the forecaster's own chance of this, stated with the estimate: 85%; the middle value lies beyond the limit too.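

No step can be read between compound 3 and compound 4 in this assay, as the result for each compound is a limit and not a number. The compounds shown leave open whether the configuration at the stereocentre at a saturated ring carbon makes any difference in this assay, and what number any of the four compounds would give there.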